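Chain Extension at the Acid of a Phthalazinone Pyridyl Series

The source may report more compounds than this note shows. Statements on the series, on what has been measured and on what is new or still open speak of the compounds shown alone.

Compound 1 `CC(=O)Cn1nc(-c2cccnc2)c2ccccc2c1=O`: 13%
Compound 2 `O=C(O)Cn1nc(-c2cccnc2)c2ccccc2c1=O`: 13%

In an assay on isolated protein (Oryctolagus cuniculus) with Thromboxane-A synthase (Homo sapiens) as the target, tested at 1 uM (on this read-out higher numbers stand for more inhibition at the one concentration tested (going by the name of the read-out) and lower numbers for less inhibition), compound 1 gives 13% and compound 2 gives 13%. Among the compounds with values here, the only step measured, no change at the digits printed from compound 1 to compound 2 (within the scatter), concerns hydroxy in place of methyl on a carbonyl carbon and left the read-out unchanged within the scatter, so compound 2 stands level with compound 1 on this assay.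

Compound 3 `O=C(O)CCCn1nc(-c2cccnc2)c2ccccc2c1=O` differs from compound 2 by 2-carboxyethyl in place of carboxy on a saturated chain carbon bound to an aromatic nitrogen. Within the data shown here, no measured step covers lengthening of this chain; the one step known touches the carbonyl carbon but not the chain length, so it gives no direction for the change. Compound 3 is therefore expected to remain near compound 2 in this assay, with the step of a number 5 percentage points higher from compound 2 to compound 3 (within the scatter) estimated as none beyond the scatter, though the range is kept wide. Compound 3 is expected to give about 18%, between 3% and 45%.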

Compound 3, a percentage reported as inhibition, at one concentration (the size of the read-out at that concentration, not a potency): 73%
For compound 3 the middle estimate is 55 percentage points below the measured one; the measured number lies above the stated range.
By their numbers in this assay, from the lowest: compounds 1 and 2 (each within the scatter of the next); then compound 3.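

In this assay, the length of the chain on the aromatic nitrogen proves decisive: carboxymethyl to 3-carboxypropyl gives a number 60 percentage points higher from compound 2 to compound 3 (beyond the scatter), a move of a kind the earlier change at the carbonyl carbon did not show. Acetyl on the same saturated chain carbon replaced by 2-carboxyethyl gives a number 60 percentage points higher from compound 1 to compound 3 (beyond the scatter), and since compound 2 already carries the carboxy group yet stands level with compound 1, the carboxy group goes with the high number only on the longer chain. Nothing available explains this rise.

On these data alone, it remains open whether a carboxyethyl or a carboxybutyl chain would hold the number, and whether an ester or an amide could stand in for the acid on the 3-carboxypropyl chain. As far as these compounds go, with a single concentration, the potency of compound 3 also stays open.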